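Allyloxy series: swapping the aminoalkylamino group for chloro

The source may hold more compounds than are shown below. What is called first, only, known or untested is meant among the compounds shown, and "the series" means these compounds.

Three compounds share the core seen in compound 1 `CC(C)COc1ccc2c(Cl)ccnc2c1` and differ in the ether chain on the oxygen and in the group on the ring carbon opposite the ring nitrogen. In a functional assay on HCT-116 cells (Homo sapiens) for cytotoxicity, read by MTT assay, with a stated time of 48 h (a lower number here means a stronger inhibitor, a higher number a weaker inhibitor), compound 1 gives 2490 nM. Compound 2 `CCOc1ccc2c(Cl)ccnc2c1`, with methyl in place of isopropyl on the chain carbon bound to the ring oxygen, gives 3160 nM; the step of a 1.3-fold higher number from compound 1 to compound 2 (0.10 log units; within the scatter) shows that the ether chain barely matters here. Compound 3 `C=CCOc1ccc2c(NCCN(C)C)ccnc2c1`, carrying the (2-(dimethylamino)ethyl)amino group and an allyloxy chain, gives 860 nM, the lowest of the three numbers, and its gaps to compound 1 and compound 2 lie beyond the scatter.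

Compound 4 `C=CCOc1ccc2c(Cl)ccnc2c1` is the chloro counterpart of compound 3: chloro in place of (2-(dimethylamino)ethyl)amino on an aromatic carbon. For the measured compounds named here, no measured step covers this exact exchange; the only step recorded concerns the ether chain, not the group on the ring carbon. What bears on it is that both chloro compounds, compound 1 and compound 2, sit well above compound 3 while their ether chains differ. Compound 4 is therefore expected to land near those two, with an upward step of about a 3.3-fold higher number from compound 3 to compound 4 (0.51 log units; beyond the scatter) in this assay. The estimate for compound 4 is 2800 nM, with a range from 1400 nM to 5600 nM.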

Compound 4, half-maximal inhibitory concentration: 2570 nM
For compound 4 the middle estimate is 1.1-fold (0.04 log units) above the measured one; the range from low to high includes it.
By their numbers in this assay, from the lowest: compound 3; then compounds 1, 4 and 2 (each within the scatter of the next).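

In this assay, the pair with the allyloxy chain held fixed isolates the group on the aromatic carbon opposite the ring nitrogen: chloro in place of (2-(dimethylamino)ethyl)amino gives a step beyond the scatter (a 3.0-fold higher number from compound 3 to compound 4 (0.48 log units; beyond the scatter)). The earlier gaps between compound 3 and the two chloro compounds also involved a different ether chain, whereas this step involves only the exchange at the ring carbon. Among the chloro compounds, the allyloxy chain adds a third ether chain with no readable effect (a 1.2-fold lower number from compound 2 to compound 4 (0.09 log units; within the scatter); a 1.0-fold higher number from compound 1 to compound 4 (0.01 log units; within the scatter)), and nothing measured here explains the step at the ring carbon.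

It remains open whether the step from chloro to the aminoalkylamino group holds with the ether chains of compound 1 and compound 2, as the compounds shown pair that group with the allyloxy chain alone. From the compounds shown here alone, it is also open how the number in this assay responds at the same ring carbon to a longer chain such as (3-(dimethylamino)propyl)amino, or to a simple primary amine.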